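From 3,4-dihydroxyphenyl to phenyl on the shared core

This account rests on a few compounds, and the source may have more. Where it says the series, first, only, none or still open, it means among the compounds named here.

Measured in a functional assay, read by spectrophotometry, with a stated time of 5 min (a higher number here means a weaker inhibitor, a lower number a stronger inhibitor), so far:
Compound 1 `CCOc1cc(/C=C/C(=O)C(=Cc2ccc(O)c(OC)c2)C(=O)/C=C/c2ccc(O)c(OCC)c2)ccc1O` gives 60500000 nM
Compound 2 `CCOc1cc(/C=C/C(=O)C(=Cc2ccc(O)c(O)c2)C(=O)/C=C/c2ccc(O)c(OCC)c2)ccc1O` gives 25200000 nM

Of these two numbers, compound 2 holds the lower one (25200000 nM), which makes it the stronger inhibitor of the pair. Compound 3 `CCOc1cc(/C=C/C(=O)C(=Cc2ccccc2)C(=O)/C=C/c2ccc(O)c(OCC)c2)ccc1O` has not been measured yet. It carries phenyl in place of 3,4-dihydroxyphenyl on a double-bonded chain carbon bound to a double-bonded chain carbon. Within the data shown here, only one measured step touches this ring: a 2.4-fold lower number from compound 1 to compound 2 (0.38 log units; beyond the scatter) when hydrogen replaced methyl on an oxygen on an aromatic ring. That step was modest but beyond the scatter. Compound 3 has no oxygen on this ring, so with that single step as a guide, a modest rise in number is expected in this assay rather than a further fall. The expected change is a 2.8-fold higher number from compound 2 to compound 3 (0.44 log units; beyond the scatter) on this estimate. The estimate for compound 3 is 70000000 nM ( expected range 25000000 nM to 200000000 nM).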

Compound 3, half-maximal inhibitory concentration: 91400000 nM
Compound 3: the middle estimate sits 1.3-fold (0.12 log units) below what was measured, within the range that was stated.
By their numbers in this assay, from the lowest: compound 2; then compounds 1 and 3 (each within the scatter of the next).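

In this assay the full loss of the ring oxygens now has a size: a 3.6-fold higher number from compound 2 to compound 3 (0.56 log units; beyond the scatter) is the result when phenyl takes the place of 3,4-dihydroxyphenyl, so at this position the two hydroxyl groups of compound 2 go with the lower number. Keeping one hydroxyl and capping the other as a methoxy gives no such edge, since a 1.5-fold higher number from compound 1 to compound 3 (0.18 log units; within the scatter) is the result when phenyl takes the place of 4-hydroxy-3-methoxyphenyl, and so compound 1 and compound 3 cannot be told apart here. Nothing measured on these compounds explains this pattern.

Which of the two hydroxyl groups carries the difference remains open, as a ring with only one of them would be needed to tell. Also open, as far as these compounds go, is how an amine or a carboxylic acid on this ring would compare with compound 2.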